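The source may hold more compounds than are shown below. What is called first, only, known or untested is meant among the compounds shown, and "the series" means these compounds.

Measured so far in a functional assay (brain) for inhibition, with Rattus norvegicus as the target; on this read-out lower numbers stand for stronger inhibition and higher numbers for weaker inhibition:
- compound 1 `CCCCCCCCCCCCCOC1=C(O)OC(C(O)CO)C1=O`: 7400 nM
- compound 2 `CCCCCCCCCCCCCCCCCCOC1=C(O)[C@@H](C(O)CO)OC1=O`: 4300 nM

For the measured compounds named here, only two numbers are available, and they lie within the usual scatter of repeated measurements. Compound 1, at 7400 nM, therefore cannot be told apart from compound 2, at 4300 nM, on this assay.

The next compound to be tested is compound 3 `CCCCCCCCCCCCCCCCCCCCCOC1=C(O)OC(C(O)CO)C1=O`. It keeps the core of compound 1 and differs only at the far end of the chain: octyl in place of hydrogen on a saturated chain carbon, ten or more bonds along the chain from an oxygen on an unsaturated carbon. Put simply, the chain of compound 3 is longer than the chain of compound 1.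

Going by the values given here, no measured pair shows on its own what such a change does in this assay, so the direction of any shift remains open. The expectation is therefore modest, with no change beyond the scatter. The expected size of the move is a 1.1-fold lower number from compound 1 to compound 3 (0.06 log units; within the scatter). For compound 3 the estimated value is 6500 nM, with an expected range of 2500 nM to 17000 nM.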

Compound 3, half-maximal inhibitory concentration: 11000 nM
Beside the measured number, compound 3's estimate is 1.7-fold (0.23 log units) below it, within the range that was stated.
By their numbers in this assay, from the lowest: compounds 2, 1 and 3 (each within the scatter of the next, the first and the last beyond it).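

In this assay, putting octyl in place of hydrogen on a saturated chain carbon, ten or more bonds along the chain from an oxygen on an unsaturated carbon, gives a 1.5-fold higher number from compound 1 to compound 3 (0.17 log units; within the scatter) and this step lies within the scatter. This is the only pair shown that differs in one place, and it shows that the far end of the chain can carry this extra length with no difference that this assay can separate from the noise of repeated measurements. No evidence is available on why the chain extension leaves the number within the scatter.

One step cannot show whether the same holds across other chain lengths, so a chain much shorter than that of compound 1 or longer than that of compound 3 remains an open case. Also open, on these data alone, is whether the far end of the chain tolerates something other than plain carbon, such as a terminal carboxylic acid or an amine, in place of the octyl of compound 3.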